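The source may report more compounds than this note shows. Statements on the series, on what has been measured and on what is new or still open speak of the compounds shown alone.

Measured compounds:
compound 1, `O=C(Oc1ccc([N+](=O)[O-])cc1)N1CCN(S(=O)(=O)c2ccc(C3CCCCC3)cc2)CC1`, 333 nM in an assay on isolated protein for inhibition of Fatty-acid amide hydrolase 1 (Homo sapiens), read by fluorescence; a higher number here means a weaker inhibitor, a lower number a stronger inhibitor
compound 2, `O=C(Oc1ccc([N+](=O)[O-])cc1)N1CCN(S(=O)(=O)c2ccc(-c3ccccc3)cc2)CC1`, 437 nM in this assay

Among the compounds with values here, compound 2 carries the higher of the two numbers, but its only neighbour is compound 1, and the step of a 1.3-fold higher number from compound 1 to compound 2 (0.12 log units; within the scatter) lies within the scatter, so the two compounds cannot be told apart on these data.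

Compound 3, `O=C(Oc1ccc([N+](=O)[O-])cc1)N1CCN(S(=O)(=O)c2ccc(Oc3ccc(Cl)c(Cl)c3)cc2)CC1`, is the next compound in the series. It differs from compound 2 in one place: 3,4-dichlorophenoxy in place of phenyl on an aromatic carbon, on an aromatic carbon of a six-membered aromatic ring of carbon only, para to a large group. Within the data shown here, no measured step bears directly on this change; the only step on record swaps a saturated ring for an aromatic one at the same position and is within the scatter. With no guidance from the measured compounds, the step is expected to be a 1.5-fold lower number from compound 2 to compound 3 (0.16 log units; within the scatter), small and not clearly beyond the scatter. Compound 3 is therefore estimated at 300 nM in this assay, with a range from 80 nM to 1200 nM.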

Compound 3, half-maximal inhibitory concentration: 317 nM
Compound 3: the middle estimate sits 1.1-fold (0.02 log units) below what was measured; the range from low to high includes it.
By their numbers in this assay, from the lowest: compounds 3, 1 and 2 (each within the scatter of the next).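

This position, on an aromatic carbon para to a large group, now carries a group with 9 heavy atoms, including two chlorines and an oxygen, where phenyl has 6 heavy atoms, and in this assay the change gives a 1.4-fold lower number from compound 2 to compound 3 (0.14 log units; within the scatter). Set against cyclohexyl, the same group gives a 1.1-fold lower number from compound 1 to compound 3 (0.02 log units; within the scatter), so the earlier finding that two ring substituents could not be told apart now extends to a third, bulkier group with a hydrogen-bond acceptor that the other two lack. No measurement on record accounts for this flat result.

All three groups carry a six-membered ring, so the compounds shown leave open whether anything at this position can move the number beyond the scatter, for example a methyl, an amine or a carboxylic acid in place of the ring. They also leave open how the number responds to changes elsewhere in the shared core, such as replacing the nitro group with a nitrile.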